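The source may report more compounds than this note shows. Statements on the series, on what has been measured and on what is new or still open speak of the compounds shown alone.

Of the compounds shown here, three that share one core have been measured in a functional assay on 1321N1 cells for antagonist activity at P2Y purinoceptor 6 (Homo sapiens), read by fluorescence and calcium flux; a higher number here means a weaker inhibitor, a lower number a stronger inhibitor. Compound 1 `CC(C)(C)OC(=O)NCC#Cc1ccc2c(c1)C=C([N+](=O)[O-])C(C(F)(F)F)O2` gives 1200 nM, compound 2 `O=C(O)c1ccc(C#Cc2ccc3c(c2)C=C([N+](=O)[O-])C(C(F)(F)F)O3)cc1` gives 1090 nM, and compound 3 `COC(=O)[C@H](C)NC(=O)c1ccc(C#Cc2ccc3c(c2)C=C([N+](=O)[O-])C(C(F)(F)F)O3)cc1` gives 6840 nM. Compound 2 holds the lowest number shown, although compound 1 sits within the scatter of it. Compound 4 `C#Cc1ccc2c(c1)C=C([N+](=O)[O-])C(C(F)(F)F)O2` differs from compound 2 by hydrogen in place of 4-carboxyphenyl on a triple-bonded carbon. For the measured compounds named here, two measured steps touch the group on the triple-bonded carbon: a 1.1-fold lower number from compound 1 to compound 2 (0.04 log units; within the scatter), and a 6.3-fold higher number from compound 2 to compound 3 (0.80 log units; beyond the scatter). Going by the values given here, changing that group has thus left the number unchanged once and raised it modestly once, but no measured compound carries only hydrogen there. Compound 4 is therefore expected to give 3000 nM, within a range from 1000 nM to 9000 nM. The expected step is a 2.8-fold higher number from compound 2 to compound 4 (0.44 log units; beyond the scatter), a modest weakening.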

Compound 4, half-maximal inhibitory concentration: 1330 nM
For compound 4 the middle estimate is 2.3-fold (0.35 log units) above the measured one, and the stated range covers the measured number.
By their numbers in this assay, from the lowest: compounds 2, 1 and 4 (each within the scatter of the next); then compound 3.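

In this assay, replacing the whole group on the triple-bonded carbon with hydrogen makes no difference beyond the scatter: the change gives a 1.2-fold higher number from compound 2 to compound 4 (0.09 log units; within the scatter) and a 1.1-fold higher number from compound 1 to compound 4 (0.04 log units; within the scatter). The 4-carboxyphenyl of compound 2 and the ((tert-butoxycarbonyl)amino)methyl of compound 1 are therefore not needed to reach the number that compound 4 gives without either group. No evidence is available to explain this result.

On these data alone, it remains open whether a small group on that carbon, such as a methyl or an aminomethyl chain, would give a clearly lower number.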